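A few compounds are considered here, and "the series" means these few. Any claim that something is new, unique, unknown or untested is made for them only; others in the source may bear on it.

The compounds measured so far:
Compound 1 `Cc1ccc(OCC(=O)NNC(=O)c2cc3ccccc3oc2=O)c(C(=O)c2ccccc2Cl)c1` — in a functional assay on Ehrlich cells (Mus musculus) for cytotoxicity, read by MTT assay, with a stated time of 48 h (on this read-out higher numbers stand for weaker inhibition and lower numbers for stronger inhibition), compound 1 gives 45200 nM
Compound 2 `Cc1ccc(OCC(=O)NNC(=O)c2cc3ccccc3oc2=O)c(C(=O)c2ccc(Cl)cc2)c1` — compound 2 gives 56600 nM
Compound 3 `Cc1ccc(OCC(=O)NNC(=O)c2cc3ccccc3oc2=O)c(C(=O)c2cccc(Br)c2)c1` — compound 3 gives 66400 nM

Compound 3 carries the highest of these three numbers, yet the two others sit close: the step of a 1.2-fold higher number from compound 2 to compound 3 (0.07 log units; within the scatter) and the step of a 1.5-fold higher number from compound 1 to compound 3 (0.17 log units; within the scatter) are both within the scatter, so the three compounds cannot be told apart on what has been measured.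

Compound 4 `Cc1ccc(C(=O)c2cc(C)ccc2OCC(=O)NNC(=O)c2cc3ccccc3oc2=O)cc1` differs from compound 3 in one place: 4-methylphenyl in place of 3-bromophenyl on a carbonyl carbon. The measured steps that bear on this change are the three exchanges of the aryl group on the same carbonyl carbon: a 1.3-fold higher number from compound 1 to compound 2 (0.10 log units; within the scatter), a 1.5-fold higher number from compound 1 to compound 3 (0.17 log units; within the scatter) and a 1.2-fold higher number from compound 2 to compound 3 (0.07 log units; within the scatter). Each of them stays within the scatter. For the measured compounds named here, none of them, however, exchanges a halogen-bearing ring for a methyl-bearing one, so the step to compound 4 has no direct precedent in these data.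

Given that every exchange of this ring so far left the number essentially unchanged, the step from compound 3 to compound 4 is expected to be a 1.1-fold lower number from compound 3 to compound 4 (0.04 log units; within the scatter), that is, none beyond the scatter. Compound 4 is therefore estimated at 60000 nM in this assay, with a range from 25000 nM to 150000 nM.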

Compound 4, half-maximal inhibitory concentration: 78100 nM
Beside the measured number, compound 4's estimate is 1.3-fold (0.11 log units) below it, within the range that was stated.
By their numbers in this assay, from the lowest: compounds 1, 2, 3 and 4 (each within the scatter of the next).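

In this assay, the 4-methylphenyl group of compound 4 does not stand apart from the halogen-bearing groups on this carbonyl carbon: the exchange for 3-bromophenyl gives a 1.2-fold higher number from compound 3 to compound 4 (0.07 log units; within the scatter) and the exchange of chloro for methyl on an aromatic carbon gives a 1.4-fold higher number from compound 2 to compound 4 (0.14 log units; within the scatter) while the exchange for 2-chlorophenyl gives a 1.7-fold higher number from compound 1 to compound 4 (0.24 log units; within the scatter) and so all three remain within the scatter. The earlier steps shown here had only exchanged one halogen-bearing ring for another, whereas these show that a ring without any halogen also leaves the four compounds indistinguishable on this read-out. No evidence is at hand that bears on this result.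

On these data alone, all four compounds keep a single simple substituent on a phenyl ring at this position, so it remains open whether a ring carrying an amine or a carboxylic acid, or a longer chain such as butyl, would move the number beyond the scatter. As far as these compounds go, it also remains open whether a change elsewhere in the shared core would do more than any exchange at this carbonyl carbon has done.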